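Replacing the bromo group of compound 2 with hydrogen

The source may hold more compounds than are shown below. What is called first, only, known or untested is meant among the compounds shown, and "the series" means these compounds.

Among the compounds with values here, the series so far holds compound 1 (`COc1ccc(/C=C/C(=O)c2ccc(N)c(-c3ccc(F)cc3)c2)cc1O`), compound 2 (`COc1cc(/C=C/C(=O)c2ccc(N)c(-c3ccc(F)cc3)c2)cc(Br)c1O`) and the unmeasured compound 3 (`COc1cc(/C=C/C(=O)c2ccc(N)c(-c3ccc(F)cc3)c2)ccc1O`). In a functional assay on CNE-2 cells (Homo sapiens) for cytotoxicity, read by sulforhodamine B assay, with a stated time of 48 h (a lower number here means a stronger inhibitor, a higher number a weaker inhibitor), the entry for compound 1 reads "not determined" (no result reported) with no result reported. Within the data shown here, compound 2 gives 25500 nM in the same test, the only number available, so it cannot yet be ranked against any neighbour. Compound 3 differs from compound 2 by one change (hydrogen in place of bromo on an aromatic carbon), hydrogen in place of bromo on an aromatic carbon, ortho to a hydroxy group. Among the measured compounds shown here, no measured step guides its size. In this assay nothing beyond the scatter is expected, and no direction is firmly favoured. The estimated step of a 1.3-fold lower number from compound 2 to compound 3 (0.11 log units; within the scatter) remains a rough expectation. In this assay compound 3 is expected at 20000 nM with an estimated range from 7000 nM to 60000 nM for this single change.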

Compound 3, half-maximal inhibitory concentration: 5750 nM
Compound 3: the middle estimate sits 3.5-fold (0.54 log units) above what was measured; the whole stated range lies above it.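

In this assay, within the data shown here, hydrogen in place of bromo on an aromatic carbon gives the first readable step: a 4.4-fold lower number from compound 2 to compound 3 (0.65 log units; beyond the scatter). This position, ortho to a hydroxy group and meta to a methoxy group, therefore responds to a single-atom change by more than the scatter, and the bromo group is not required for the activity seen in compound 2, since compound 3 gives the lower number without it. The data on hand offer no explanation for the size or direction of this step.

Steps involving compound 1 cannot be read, so only bromo and hydrogen can be compared at this position. On these data alone, whether a fluoro, chloro, methyl or amino group here would sit closer to compound 2 or to compound 3 remains open.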